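A few compounds are considered here, and "the series" means these few. Any claim that something is new, unique, unknown or untested is made for them only; others in the source may bear on it.

Measured so far in a functional assay on DU-145 cells (Homo sapiens) for antiproliferative activity, read by WST assay, with a stated time of 72 h; on this read-out higher numbers stand for an effect only at larger amounts of compound and lower numbers for an effect already at smaller amounts:
compound 1, `CCCCCCCC/C=C\c1c(C)c(/C=C/CCCCCCCC)c2[n+](c1C)CCC2`, gives 0.2 uM
compound 2, `CCCCCCCC/C=C\c1c(C)c(/C=C/CCCCCCCC)c(C)[n+]2c1CCC2`, gives 0.8 uM
compound 3, `CCCCCCCCCCc1c(C)cc(C)[n+]2c1CCC2`, gives 0.5 uM

Compound 1 gives the lowest of the three numbers in this assay. Compound 3 lies closest to it, and its number is higher by more than the scatter; compound 2 lies furthest away. Among the measured compounds shown here, the only measured step between compounds that differ in one place is a 4.0-fold higher number from compound 1 to compound 2 (0.60 log units; beyond the scatter), and it rests on (the fact that compounds 1 and 2 differ only in the configuration as drawn), so it concerns configuration alone and does not speak to removing a chain.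

Compound 4, `CCCCCCCC/C=C/c1c(C)cc(C)[n+]2c1CCC2`, is reached from compound 1 by hydrogen in place of dec-1-en-1-yl on an aromatic carbon. For the measured compounds named here, no measured step follows that same change. What the values do show is that compound 3, which also carries only a single chain on the shared core, gives a higher number than compound 1 in this assay, beyond the scatter. On that basis a modest rise is expected for compound 4, estimated as a 2.5-fold higher number from compound 1 to compound 4 (0.40 log units; beyond the scatter). Compound 4 is therefore expected to give about 0.5 uM in this assay, within a range from 0.2 uM to 1.3 uM.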

Compound 4, concentration for half-maximal effect: 0.6 uM
Compound 4: the middle estimate sits 1.2-fold (0.08 log units) below what was measured; low and high end bracket the measured number.
By their numbers in this assay, from the lowest: compound 1; then compounds 3, 4 and 2 (each within the scatter of the next).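

In this assay, among the compounds shown here, replacing the dec-1-en-1-yl on this aromatic carbon, ortho to two methyl groups and two atoms from the ring nitrogen, with hydrogen gives a 3.0-fold higher number from compound 1 to compound 4 (0.48 log units; beyond the scatter), the first measured step at this position, as the only earlier step concerned configuration alone. The step is modest: without this chain, compound 4 still gives 0.6 uM, so the chain goes with the lower number of compound 1, but the effect in this assay does not depend on its presence. Nothing shown here gives a reason for this step.

The compounds shown place only hydrogen or dec-1-en-1-yl on this carbon, so it remains open how a shorter chain such as butyl, a saturated decyl chain, a longer chain, or a small group such as hydroxyl or an amine would place a compound relative to these two. On these data alone, it also remains open whether the step would keep its size with the other configuration of the double bond in the remaining chain.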